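Pyrazole Carboxylic Acids Tested for Antiproliferative Activity

This account rests on a few compounds, and the source may have more. Where it says the series, first, only, none or still open, it means among the compounds named here.

Measured compounds:
Compound 1, `COc1cccc(-c2c(C)nn(-c3nc(-c4ccc(Cl)c(Cl)c4)c(SC(C)C)s3)c2C(=O)O)c1`: 14000 nM
Compound 2, `Cc1nn(-c2nc(-c3ccc(Cl)c(Cl)c3)c(SC(C)C)s2)c(C(=O)O)c1-c1cccc(Cl)c1C`: 5100 nM

In a functional assay on BJAB cells (Homo sapiens) for antiproliferative activity, with a stated time of 4 days (a higher number here means that more compound is needed for the effect, a lower number that less compound is needed), compound 1 gives 14000 nM and compound 2 gives 5100 nM. Compound 2 stands as the lower of the two numbers, with a 2.7-fold lower number from compound 1 to compound 2 (0.44 log units; beyond the scatter) placing it apart from compound 1 by a modest but real margin. The change that produced this step was a swap of the aryl group on the shared core: 3-chloro-2-methylphenyl in place of 3-methoxyphenyl on an aromatic carbon.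

Compound 3, `COc1cc(Cl)cc(-c2c(C)nn(-c3nc(-c4ccc(Cl)c(Cl)c4)c(SC(C)C)s3)c2C(=O)O)c1`, is the next step from compound 2. The change is 3-chloro-5-methoxyphenyl in place of 3-chloro-2-methylphenyl on an aromatic carbon. Among the compounds with values here, the new group carries the chlorine seen in compound 2 and the methoxy seen in compound 1, so the only step that bears on it is the one from compound 1 to compound 2, and it points in no clear direction for this mixed substitution. Compound 3 is therefore expected to land between its two neighbours, with a 1.8-fold higher number from compound 2 to compound 3 (0.25 log units; within the scatter) as the estimated step. Compound 3 is estimated at 9000 nM in this assay, within a range of 3000 nM to 25000 nM.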

Compound 3, half-maximal effective concentration: 760 nM
The estimate for compound 3 lay 12-fold (1.07 log units) above the measured number; the whole stated range lies above it.
By their numbers in this assay, from the lowest: compound 3; then compound 2; then compound 1.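

In this assay the aryl group on this aromatic carbon of the five-membered ring proves more sensitive than the earlier pair could show: 3-chloro-5-methoxyphenyl in place of 3-chloro-2-methylphenyl gives a 6.7-fold lower number from compound 2 to compound 3 (0.83 log units; beyond the scatter) and so, with a chlorine on both rings, the chlorine alone does not set the number. Chloro in place of hydrogen on the 3-methoxyphenyl ring gives an 18-fold lower number from compound 1 to compound 3 (1.27 log units; beyond the scatter) and this single added atom moves the number further than either exchange of one substituted phenyl for another, leaving compound 3 with the lowest number of the three. No measurement at hand gives a reason for these steps.

From the compounds shown here alone, whether the low number of compound 3 depends on the methoxy group itself remains open, as does whether an ethoxy group or a fluoro substituent could take its place on the ring. All three compounds also keep the carboxy group on the shared core, so they do not tell how an amide there would behave in this assay.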